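The compounds below may be only part of what the source reports. "The series", "measured", "known", "first", "only" and "open" are said of these compounds alone.

Measured in a functional assay on MCF7 cells (Homo sapiens) for antiproliferative activity, read by MTT assay, with a stated time of 72 h; a lower number here means a stronger inhibitor, a higher number a weaker inhibitor:
- compound 1 `CCC/C=C/C(=O)Nc1cccc(Oc2nc(Nc3ccc(OC)cc3)nc3c2CSCC3)c1`: > 50000 nM
- compound 2 `COc1ccc(Nc2nc3c(c(Oc4cccc(NC(=O)C=C(C)C)c4)n2)CSCC3)cc1`: > 50000 nM
- compound 3 `COc1ccc(Nc2nc3c(c(Oc4cccc(NC(=O)/C=C/C(C)C)c4)n2)CSCC3)cc1`: > 50000 nM

Each of these entries is a limit and not a number: the limit of > 50000 nM in this assay, at which 3 of the 3 values shown sit. Compound 1 therefore has no number of its own, only its limit of > 50000 nM.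

Compound 4 `CCC/C=C/C(=O)Nc1cccc(Oc2nc(Nc3ccc(OC)nc3)nc3c2CSCC3)c1` carries 6-methoxypyridin-3-yl in place of 4-methoxyphenyl on a nitrogen on an aromatic ring. Among the compounds with values here, no measured step touches that place. The three measured steps all change the group on the carbonyl carbon: a step that the two limits leave unreadable from compound 1 to compound 2, a step that the two limits leave unreadable from compound 1 to compound 3 and a step that the two limits leave unreadable from compound 2 to compound 3. None of them has a readable size, so they give no guide to the size or direction of this change.

The expectation rests on compound 1 alone, whose limit is > 50000 nM. No shift beyond the scatter is expected in this assay, and no direction can be given. The expected step is a number no higher from compound 1 to compound 4 (the limit leaves the size open). Compound 4 is estimated at 50000 nM, with an expected range of 20000 nM to 100000 nM.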

Compound 4, half-maximal inhibitory concentration: 26800 nM
Compound 4: middle estimate off by 1.9-fold (0.27 log units), on the high side; the measured number falls inside the stated range.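

In this assay, compound 4 alone among the compounds shown gives a number, 26800 nM, so the place on a nitrogen on an aromatic ring is the only one here tied to a measurable antiproliferative value. Putting 6-methoxypyridin-3-yl in place of 4-methoxyphenyl gives an at least 1.8-fold lower number from compound 1 to compound 4 (0.27 log units; that floor lies within the scatter), so the change has a floor that does not pass the scatter. The full size of the step stays unknown because compound 1 has only a limit: the limit of > 50000 nM in this assay, at which 3 of the 4 values shown sit.

As far as these compounds go, the steps among compound 1, compound 2 and compound 3 cannot be read, so it remains open whether 6-methoxypyridin-3-yl would act the same way with the other groups on the carbonyl carbon. Also open, from the compounds shown here alone, is how an amine or a carboxylic acid in place of the methoxy group would read in this assay.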